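Fluoro for hydrogen on the sulfonyl phenyl of compound 3

The compounds below may be only part of what the source reports. "The series", "measured", "known", "first", "only" and "open" are said of these compounds alone.

Of the compounds shown here, three sharing one core have been measured in an assay on isolated protein for displacement of a labelled ligand from metabotropic glutamate receptor 5 (Homo sapiens), with a stated time of 60 min, tested at 1 uM; a lower number here means less inhibition, a higher number more inhibition at the concentration tested (going by the name of the read-out). Compound 1 `Cc1cc(C)cc(S(=O)(=O)c2cnc3cc(F)ccc3c2N2CCC(C)CC2)c1` gives 80%, compound 2 `CC1CCN(c2c(S(=O)(=O)c3cccc(C#N)c3)cnc3cc(F)ccc23)CC1` gives 92%, and compound 3 `CC1CCN(c2c(S(=O)(=O)c3ccccc3)cnc3cc(F)ccc23)CC1` gives 87%. Compound 3 stands second highest of the three numbers, but its gap to compound 2 and its gap to compound 1 are both within the scatter, so the three are not separated in this assay.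

Compound 4 `CC1CCN(c2c(S(=O)(=O)c3ccc(F)cc3)cnc3cc(F)ccc23)CC1` has not been measured. It differs from compound 3 by fluoro in place of hydrogen on an aromatic carbon, sitting para to a large group on the six-membered ring of carbon only that is attached to the sulfonyl sulfur.

Two of the measured steps concern changes on that same ring. Going from 3,5-dimethylphenyl to phenyl gave a number 7 percentage points higher from compound 1 to compound 3 (within the scatter), and removing the cyano gave a number 5 percentage points lower from compound 2 to compound 3 (within the scatter). Neither step left the scatter, so the assay has so far been little moved by substituents on this ring, and the account therefore expects no step beyond the scatter: a number 1 percentage points higher from compound 3 to compound 4 (within the scatter). On this basis compound 4 is estimated to give 88% in this assay, with a range from 78% to 96%.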

Compound 4, a percentage reported as inhibition, at one concentration (the size of the read-out at that concentration, not a potency): 74.5%
The estimate for compound 4 lay 13.5 percentage points above the measured number, and the stated range ends above it.
By their numbers in this assay, from the lowest: compounds 4, 1, 3 and 2 (each within the scatter of the next, the first and the last beyond it).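

In this assay, among these compounds, the ring on the sulfonyl sulfur proves sensitive to a single small atom: fluoro in place of hydrogen, para to a large group, gave a number 12.5 percentage points lower from compound 3 to compound 4 (beyond the scatter), the first step on this ring to go downward beyond the scatter. Compound 4 also falls clearly short of the nitrile-bearing ring, with a number 17.5 percentage points lower from compound 2 to compound 4 (beyond the scatter), while a number 5.5 percentage points lower from compound 1 to compound 4 (within the scatter) leaves 4-fluorophenyl not separated from 3,5-dimethylphenyl, so substituents on this ring can separate compounds in both directions, though not in every pair. Nothing measured here bears on why one fluoro should produce this step.

The compounds shown leave open whether the step belongs to fluoro itself or to this place on the ring, since a chloro or methoxy group or an amine at the same carbon, or a fluoro at another carbon of the ring, would be needed to tell these apart. They also leave open how far the step carries over to potency, since this assay reports only the size of the read-out at one concentration.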